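A few compounds are considered here, and "the series" means these few. Any claim that something is new, unique, unknown or untested is made for them only; others in the source may bear on it.

Measured in an ADME assay on MT4 cells (Homo sapiens) for cytotoxicity, read by MTT assay, with a stated time of 96 h; on this read-out lower numbers stand for higher toxicity in this test and higher numbers for lower toxicity in this test:

Compound 1 `CCC(=O)Oc1ccc2ccc(=O)oc2c1Cc1c(-c2ccccc2)[nH]c2ccccc12`: > 100000 nM (a limit, not a number)
Compound 2 `Cc1[nH]c2ccccc2c1Cc1c(OC(=O)CCCC(=O)O)ccc2ccc(=O)oc12`: 27000 nM
Compound 3 `CCC(=O)Oc1ccc2ccc(=O)oc2c1Cc1c(C)[nH]c2ccccc12`: 80000 nM

Compound 3 holds the higher of the two actual numbers, with compound 2 lying below it, while compound 1 gives only a limit. Compound 4 `CCC(=O)Oc1ccc2c(C)cc(=O)oc2c1Cc1c(C)[nH]c2ccccc12` differs from compound 3 by methyl in place of hydrogen on an aromatic carbon, opposite the ring oxygen (methyl in place of hydrogen on an aromatic carbon). Neither measured step makes this change. The closer in kind is methyl in place of phenyl on an aromatic carbon, which gave an at least 1.2-fold lower number from compound 1 to compound 3 (0.09 log units; that floor lies within the scatter), but that step starts from a limit and concerns a different carbon. The other replaces carboxymethyl with hydrogen on a saturated chain carbon and gave a 3.0-fold higher number from compound 2 to compound 3 (0.47 log units; beyond the scatter), a modest step at a place where compound 4 does not differ from compound 3. With so little direct support, a single added methyl is expected to shift the number only slightly. The estimated step in this assay is a 1.2-fold lower number from compound 3 to compound 4 (0.09 log units; within the scatter), which is expected to stay within the scatter. For compound 4 the expected value is 65000 nM, with an estimated range from 28000 nM to 100000 nM.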

Compound 4, half-maximal cytotoxic concentration: 31000 nM
For compound 4 the middle estimate is 2.1-fold (0.32 log units) above the measured one; measured number inside the range.
By their numbers in this assay, from the lowest: compounds 2 and 4 (each within the scatter of the next); then compound 3. At a limit, above all of these: compound 1.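

In this assay, methyl in place of hydrogen on the aromatic carbon opposite the ring oxygen gives a 2.6-fold lower number from compound 3 to compound 4 (0.41 log units; beyond the scatter). Among the compounds shown here, the earlier steps touched only the ester chain and the aromatic carbon carrying phenyl or methyl, so this is the first sign that this carbon of the shared core also bears on the number, here in the direction of higher toxicity in this test. A change of a single heavy atom, with no ring, no hydrogen-bond donor or acceptor and no net charge, is thus enough to carry the number beyond the scatter, though the step is still a modest one and rests on one pair of compounds.

From the compounds shown here alone, what a chlorine, an amine or a longer chain would do at this same carbon stays open, as does whether methyl here would move the number in the same way with the phenyl group of compound 1 or the ester chain of compound 2 in place. Compound 1 gives only a limit of the assay, not a number, so it offers no measured baseline for such a comparison: the limit of > 100000 nM in this assay, at which 1 of the 4 values shown sits.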